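Second Chloro on the Carbamate of Compound 3

The source may report more compounds than this note shows. Statements on the series, on what has been measured and on what is new or still open speak of the compounds shown alone.

Compound 3 `CC(C)=CCC1Cc2c(OC(=O)Nc3ccc(Cl)cc3)cc(=O)n(CCCO)c2CC1(C)C` stands highest of the three compounds measured in a functional assay on PANC-1 cells (Homo sapiens) for inhibition, read by MTT assay, with a stated time of 24 h, tested at 10 uM; a higher number here means more inhibition at the concentration tested (going by the name of the read-out), a lower number less inhibition: compound 3 gives 49.8%. Compound 1 `CC(C)=CCC1Cc2c(OCc3ccccc3)cc(=O)n(CCCO)c2CC1(C)C` gives -0.3% and compound 2 `CC(C)=CCC1Cc2c(OCCCNC(=O)c3ccco3)cc(=O)n(CCCO)c2CC1(C)C` gives 2.1%. The steps of a number 50.1 percentage points higher from compound 1 to compound 3 (beyond the scatter) and a number 47.7 percentage points higher from compound 2 to compound 3 (beyond the scatter) are both large, while a number 2.4 percentage points higher from compound 1 to compound 2 (within the scatter) stays within the scatter. Compound 4 `CC(C)=CCC1Cc2c(OC(=O)Nc3ccc(Cl)c(Cl)c3)cc(=O)n(CCCO)c2CC1(C)C` differs from compound 3 in one place: chloro in place of hydrogen on an aromatic carbon. Within the data shown here, no measured step speaks directly to this change: the two large steps concern replacement of the whole group on the aromatic oxygen by the (4-chlorophenyl)carbamoyl group, not a further substituent on that group. The value of compound 3 is therefore the only anchor, and the (4-chlorophenyl)carbamoyl feature is retained in compound 4. The step of a number 5.2 percentage points higher from compound 3 to compound 4 (within the scatter) is expected to be small, with no direction beyond the scatter predicted. Compound 4 is estimated at 55% in this assay, within a range of 30% to 80%.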

Compound 4, a percentage reported as inhibition, at one concentration (the size of the read-out at that concentration, not a potency): 61.4%
Estimate against measurement, compound 4: 6.4 percentage points below; measured number inside the range.
By their numbers in this assay, from the lowest: compounds 1 and 2 (each within the scatter of the next); then compound 3; then compound 4.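

In this assay, among these compounds, the earlier compounds showed only that the (4-chlorophenyl)carbamoyl group on the oxygen set compound 3 apart from the other two, whereas the step of a number 11.6 percentage points higher from compound 3 to compound 4 (beyond the scatter) shows that the ring of that group still responds to one added chloro, ortho to a chloro group and meta to a large group. The (3,4-dichlorophenyl)carbamoyl group also stands well clear of the other two groups on the oxygen, with a number 59.3 percentage points higher from compound 2 to compound 4 (beyond the scatter) and a number 61.7 percentage points higher from compound 1 to compound 4 (beyond the scatter) both large. Nothing at hand bears on why this added chloro goes with a higher number. From the compounds shown here alone, whether the rise belongs to chloro itself remains open, since a fluoro, a methyl or a methoxy group at this position could give a similar number or a different one. Going by these compounds, it also remains open how a carbamate carrying an unsubstituted phenyl group would compare with compound 3.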